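Bis(trifluoromethyl)benzenesulfonamide series: ortho methoxy replaces chloro

A few compounds are considered here, and "the series" means these few. Any claim that something is new, unique, unknown or untested is made for them only; others in the source may bear on it.

Measured so far:
compound 1 `O=S(=O)(NCCCNCc1ccccc1Cl)c1cc(C(F)(F)F)cc(C(F)(F)F)c1` gives 15000 nM
compound 2 `COc1ccc(CNCCCNS(=O)(=O)c2cc(C(F)(F)F)cc(C(F)(F)F)c2)cc1` gives 2800 nM

In a functional assay on BE(2)-C cells (Homo sapiens) for inhibition, read by MTT assay, with a stated time of 72 h (a lower number here means a stronger inhibitor of growth, a higher number a weaker inhibitor of growth), compound 1 stands highest of the two numbers. Among the compounds with values here, the only measured step, a 5.4-fold lower number from compound 1 to compound 2 (0.73 log units; beyond the scatter), pairs a change of group with a change of place on the ring, so it bears only loosely on the step to compound 3 `COc1ccccc1CNCCCNS(=O)(=O)c1cc(C(F)(F)F)cc(C(F)(F)F)c1`, which differs from compound 1 by methoxy in place of chloro on an aromatic carbon. Within the data shown here, since the one known exchange of chloro for methoxy lowered the number, a step downward is expected, but smaller and less certain than the measured one. For compound 3 the estimate is 6000 nM (range 2000 nM to 18000 nM), meaning an expected step of a 2.5-fold lower number from compound 1 to compound 3 (0.40 log units; beyond the scatter).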

Compound 3, concentration for 50% growth inhibition: 3600 nM
Estimate against measurement, compound 3: 1.7-fold (0.22 log units) above; low and high end bracket the measured number.
By their numbers in this assay, from the lowest: compounds 2 and 3 (each within the scatter of the next); then compound 1.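

The direct exchange of chloro for methoxy on an aromatic carbon, in this assay, isolates this change and moves the number beyond the scatter (a 4.2-fold lower number from compound 1 to compound 3 (0.62 log units; beyond the scatter)). The methoxy position does not separate the two methoxy compounds, since 2-methoxyphenyl and 4-methoxyphenyl lie within the scatter (a 1.3-fold higher number from compound 2 to compound 3 (0.11 log units; within the scatter)). No evidence available here bears on the reason for either step.

Going by these compounds, whether an amine or a nitrile on that aromatic carbon would track with methoxy or with chloro remains open. So does the effect of a longer chain between the sulfonamide nitrogen and the benzylic amine.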